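This account rests on a few compounds, and the source may have more. Where it says the series, first, only, none or still open, it means among the compounds named here.

Measured so far:
Compound 1, `CC(C)c1ccc(NC(=O)N[C@@H](C)c2ccccc2)cc1`, gives 96% in an ADME assay on the whole organism with Oryza sativa as the target, tested at 1 uM; on this read-out lower numbers stand for a stronger effect and higher numbers for a weaker effect at the one concentration tested.
Compound 2, `C[C@@H](NC(=O)Nc1ccccc1C(C)(C)C)c1ccccc1`, gives 95% in this assay.
Compound 3, `C[C@H](NC(=O)Nc1ccccc1C(C)(C)C)c1ccccc1`, gives 99% in this assay.

Compound 3 stands at the top of the three numbers as written, yet compound 1 and compound 2 both lie within the scatter of it, so the three cannot be told apart on this read-out. Among the measured compounds shown here, the only step measured among them, a number 4 percentage points higher from compound 2 to compound 3 (within the scatter), rests on the fact that compounds 2 and 3 differ only in the configuration as drawn and is itself within the scatter.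

Compound 4, `C[C@H](NC(=O)Nc1ccccc1Cl)c1ccccc1`, is not yet measured. It differs from compound 3 by chloro in place of tert-butyl on an aromatic carbon. For the measured compounds named here, no measured step swaps one group for another on that aromatic carbon; the single step on record concerns configuration only, so it offers no guide to the size of this change. The expectation therefore rests on the tight cluster of the three measured numbers and carries a wide range. Compound 4 is expected to give 94%, between 80% and 100%, which means an expected step of a number 5 percentage points lower from compound 3 to compound 4 (within the scatter), no change beyond the scatter.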

Compound 4, a percentage reported as activity, at one concentration (the size of the read-out at that concentration, not a potency): 104%
Compound 4: middle estimate off by 10 percentage points, on the low side, and the stated range ends below it.
By their numbers in this assay, from the lowest: compounds 2, 1, 3 and 4 (each within the scatter of the next).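

Replacing tert-butyl, with 4 heavy atoms, by chloro, with 1 heavy atom, on this aromatic carbon gives a step in this assay that cannot be told from the scatter: a number 5 percentage points higher from compound 3 to compound 4 (within the scatter). Among the compounds shown here, the earlier compounds showed only a change of configuration, so this pair is the first to test a change of group at this place, and a large cut in group size leaves no measurable mark on the read-out. This holds for this one pair alone, and nothing on record explains it.

On these data alone, whether a different group on the same aromatic carbon, such as an amine, a methoxy or a carboxylic acid, would move the number beyond the scatter remains open. Also open, as far as these compounds go, is whether any change to the shared core can produce a clear effect in this assay at all.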